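From compound 2 to compound 3: a cyano exchange

This account rests on a few compounds, and the source may have more. Where it says the series, first, only, none or still open, it means among the compounds named here.

Measured compounds, with values from a functional assay on VCaP cells (Homo sapiens) for antiproliferative activity, read by propidium iodide staining, with a stated time of 96 h (on this read-out lower numbers stand for stronger inhibition and higher numbers for weaker inhibition), throughout
Compound 1 `CC(O)(CSc1cc(C(F)(F)F)cc(C(F)(F)F)c1)C(=O)Nc1ccc(S(F)(F)(F)(F)F)cc1` gives 19400 nM
Compound 2 `CC(O)(COc1ccc(S(F)(F)(F)(F)F)cc1)C(=O)Nc1ccc(S(F)(F)(F)(F)F)cc1` gives 9300 nM

Of the two measured compounds, compound 2 has the lower number and so the stronger inhibition, and its gap to compound 1 lies just beyond the usual scatter. Compound 3 `CC(O)(COc1ccc(C#N)cc1)C(=O)Nc1ccc(S(F)(F)(F)(F)F)cc1` has not yet been measured. It keeps the rest of compound 2 and differs in one place (a group of 2 heavy atoms (1 carbon, 1 nitrogen; no ring) in place of a group of 6 heavy atoms (5 fluorine, 1 sulfur; no ring), on an aromatic carbon): a cyano group stands in place of a group of 6 heavy atoms (5 fluorine, 1 sulfur; no ring), on an aromatic carbon, para to a large group.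

Within the data shown here, no measured pair shows this exchange, so there is no direct precedent for its size. In this assay a small step towards weaker inhibition is expected, not clearly beyond the scatter. The expected move is a 1.6-fold higher number from compound 2 to compound 3 (0.21 log units; within the scatter) in this estimate. The estimated value for compound 3 is 15000 nM (expected range 6000 nM to 35000 nM).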

Compound 3, half-maximal inhibitory concentration: 100000 nM
Compound 3: middle estimate off by 6.7-fold (0.82 log units), on the low side; the whole stated range lies below it.
By their numbers in this assay, from the lowest: compound 2; then compound 1; then compound 3.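

In this assay, the exchange of the group of 6 heavy atoms (5 fluorine, 1 sulfur) for cyano, on an aromatic carbon of a six-membered aromatic ring of carbon only and para to a large group, gives an 11-fold higher number from compound 2 to compound 3 (1.03 log units; beyond the scatter) and so counts as a large step. Compound 1 and compound 2 differ in more than one place and could not isolate this position, whereas this single exchange shows that, with the rest of compound 2 held constant, the group at this place strongly affects the antiproliferative read-out. Nothing measured here bears on why the step is so large.

Two compounds at this place cannot show whether the loss follows from the departure of the group of 6 heavy atoms or from the arrival of cyano, and a chlorine atom, a methyl group or a nitro group there could help to tell these apart. Going by these compounds, it also remains open whether the same exchange would cost as much at the second copy of that group, which compound 2 and compound 3 both keep.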